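From compound 2 to compound 3 at the assay limit

The source may report more compounds than this note shows. Statements on the series, on what has been measured and on what is new or still open speak of the compounds shown alone.

In a functional assay on A549 cells (Homo sapiens) for cytotoxicity, read by MTT assay, with a stated time of 48 h (a lower number here means a stronger inhibitor, a higher number a weaker inhibitor), compound 1 `COc1cc2c(cc1OC)CN(S(=O)(=O)c1ccc(-n3cc(COc4ccccc4C(C)=O)nn3)cc1)CC2` reads > 50 ug/mL, which is a limit of the assay. Compound 2 `COc1cc2c(cc1OC)CN(S(=O)(=O)c1ccc(-n3cc(COc4ccc(C)cc4)nn3)cc1)CC2` reads > 50 ug/mL, also a limit. The series therefore stands at the limit of > 50 ug/mL in this assay, at which 2 of the 2 values shown sit, and compound 2 has no number to start from. Compound 3 `COc1cc2c(cc1OC)CN(S(=O)(=O)c1ccc(-n3cc(COc4ccc(C=O)cc4OC)nn3)cc1)CC2` carries 4-formyl-2-methoxyphenyl in place of 4-methylphenyl on an oxygen on a saturated carbon. For the measured compounds named here, the only measured step at this place is a step that the two limits leave unreadable from compound 1 to compound 2, so it gives no size or direction to carry over. The expected change is a step that the limit leaves unreadable from compound 2 to compound 3, with nothing beyond the scatter anticipated. For compound 3 the estimated value is 60 ug/mL, within 30 ug/mL to 120 ug/mL.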

Compound 3, half-maximal inhibitory concentration: > 50 ug/mL
Compound 3: only a limit was reported (the forecaster's own chance of this, stated with the estimate: 75%); the middle value is on the limit's open side.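

Compound 1, compound 2 and compound 3 all stand at a limit in this assay, so no step among them can be read: the limit of > 50 ug/mL in this assay, at which 3 of the 3 values shown sit.

The compounds shown leave open whether any group at this place gives a readable value, and how large any step would be.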